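This account rests on a few compounds, and the source may have more. Where it says the series, first, only, none or still open, it means among the compounds named here.

Compound 1 `N#Cc1c(Nc2nccs2)nc(SCc2nc3ccccc3[nH]2)nc1-c1ccccc1`: 11.9 nM
Compound 2 `N#Cc1c(-c2ccccc2)nc(SCc2nc3ccccc3[nH]2)nc1N1CCNCC1`: 2.5 nM

Among the compounds with values here, in a functional assay on G-361 cells (Homo sapiens) for cytotoxicity, read by MTT assay, with a stated time of 3 days (on this read-out lower numbers stand for stronger inhibition and higher numbers for weaker inhibition), compound 2 gives 2.5 nM, the lowest of the two numbers so far. Within the data shown here, the only measured step, a 4.8-fold lower number from compound 1 to compound 2 (0.68 log units; beyond the scatter), is modest and replaces (1,3-thiazol-2-yl)amino with piperazin-1-yl on an aromatic carbon. Compound 3 `N#Cc1c(-c2ccccc2)nc(SCc2nc3ccccc3[nH]2)nc1N1CCN(S(=O)(=O)c2ccccc2)CC1` keeps that piperazin-1-yl group but adds to it: phenylsulfonyl in place of hydrogen on an amine nitrogen in a ring. Among the measured compounds shown here, no measured compound carries anything on that nitrogen, so the evidence is indirect. It shows only that changing this part of compound 2 can shift the number by a modest amount, as in a 4.8-fold lower number from compound 1 to compound 2 (0.68 log units; beyond the scatter). Starting from the lowest value, a modest rise is expected, namely a 2.8-fold higher number from compound 2 to compound 3 (0.45 log units; beyond the scatter). The estimate for compound 3 is 7 nM, with an expected range from 1.5 nM to 30 nM.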

Compound 3, half-maximal inhibitory concentration: 8.62 nM
Compound 3: the middle estimate sits 1.2-fold (0.09 log units) below what was measured, within the range that was stated.
By their numbers in this assay, from the lowest: compound 2; then compounds 3 and 1 (each within the scatter of the next).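

Within the data shown here, compound 3 is the first compound here with anything on this amine nitrogen in a ring, and in this assay phenylsulfonyl in place of hydrogen gives a 3.4-fold higher number from compound 2 to compound 3 (0.54 log units; beyond the scatter). The step is beyond the usual scatter, so the free nitrogen of compound 2 and its substituted form can be told apart, although the change is only modest. This nitrogen therefore carries a group of this size, with its six-membered aromatic ring of carbon, while compound 3 still gives 8.62 nM on this cell-killing read-out.

From the compounds shown here alone, whether a small methyl or acetyl group on the same nitrogen would give a number nearer that of compound 2 or that of compound 3 remains open. Nothing measured here explains why the number rises with phenylsulfonyl.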